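The source may report more compounds than this note shows. Statements on the series, on what has been measured and on what is new or still open speak of the compounds shown alone.

Measured so far in a functional assay on A-375 cells (Homo sapiens) for inhibition, read by CCK-8 assay, with a stated time of 72 h, tested at 8 uM; on this read-out higher numbers stand for more inhibition of growth at the one concentration tested and lower numbers for less inhibition of growth:
- compound 1 `COc1ccc(SCc2ccc(C(=O)Nc3ccccc3N)cc2)cc1`: 81.8%
- compound 2 `Nc1ccccc1NC(=O)/C=C/c1ccc(CSc2ccc(C(F)(F)F)cn2)cc1`: 3.96%

Compound 1 stands highest of the two numbers available. Within the data shown here, the only other measured compound, compound 2, differs from it at several places at once and gives a far lower result, 3.96%, a gap well beyond the usual scatter; no single-point step connects the two, so nothing more is drawn from that pair than what the two values show.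

The next compound in the series is compound 3 `Cc1cc(C)cc(SCc2ccc(C(=O)Nc3ccccc3N)cc2)c1`. It is compound 1 with one change: 3,5-dimethylphenyl in place of 4-methoxyphenyl on a sulfur. The group that leaves and the group that enters are both six-membered aromatic rings of eight heavy atoms, attached at the same sulfur.

Among the measured compounds shown here, no step of this kind between measured compounds is known, so the size of the step in this assay is uncertain. A modest step downward from compound 1 is expected, and one that may well stay within the scatter. The expected step is a number 11.8 percentage points lower from compound 1 to compound 3 (beyond the scatter). Compound 3 is estimated at 70% in this assay, with a range from 45% to 90%.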

Compound 3, percent growth inhibition at one concentration: 74.7%
For compound 3 the middle estimate is 4.7 percentage points below the measured one, and the stated range covers the measured number.
By their numbers in this assay, from the lowest: compound 2; then compounds 3 and 1 (each within the scatter of the next).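

In this assay, the series now has a step that changes one place only, on a sulfur whose other neighbour is a saturated chain carbon, and it reads as follows: a number 7.1 percentage points lower from compound 1 to compound 3 (within the scatter). Compound 3 carries 3,5-dimethylphenyl, with no oxygen and no hydrogen-bond acceptor in that group, so the oxygen and the acceptor counted in the 4-methoxyphenyl of compound 1 are not needed for a value in this range at the one concentration tested, and the two substitution patterns on the aromatic ring cannot be told apart here. No independent measurement on these compounds bears on the result, so this stays a reading of two numbers with no explanation attached.

Open remains whether a value in this range holds when the aromatic ring on the sulfur gives way to a longer saturated chain such as hexyl, or when that ring carries an amine or a carboxylic acid. Among these compounds, also open is which of the several differences between compound 2 and the other two compounds goes with its low number, as no single-place step connects compound 2 to either of them.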